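This account rests on a few compounds, and the source may have more. Where it says the series, first, only, none or still open, it means among the compounds named here.

Working notes on the series.

Compound 3 `CC(C)C[C@H](NC(=O)CN(c1nc(Cl)nc2[nH]cnc12)C1CC1)C(=O)OCc1ccccc1` gives 8.58% in a functional assay on the whole organism (Tail, strain ICR) with Mus musculus as the target, in the tail flick test, with a stated time of 120 min, at a dose of 25 umol/kg by the oral route (a lower number here means a weaker effect, a higher number a stronger effect of the compound at the dose given), and stands lowest of the three numbers measured. Compound 1 `NCCCC[C@H](NC(=O)CN(c1nc(Cl)nc2[nH]cnc12)C1CC1)C(=O)OCc1ccccc1` gives 16.8% and compound 2 `CC[C@H](C)[C@H](NC(=O)CN(c1nc(Cl)nc2[nH]cnc12)C1CC1)C(=O)OCc1ccccc1` gives 22%; the step of a number 8.2 percentage points lower from compound 1 to compound 3 (within the scatter) is within the scatter, while a number 13.4 percentage points lower from compound 2 to compound 3 (beyond the scatter) is beyond it, and a number 5.2 percentage points higher from compound 1 to compound 2 (within the scatter) is within it.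

Compound 4 `O=C(CN(c1nc(Cl)nc2[nH]cnc12)C1CC1)N[C@@H](CO)C(=O)OCc1ccccc1` is not yet measured. It differs from compound 3 by hydroxy in place of isopropyl on a saturated chain carbon, two bonds along the chain from an amide-type nitrogen and a carbonyl carbon. Among the measured compounds shown here, the one measured step that bears on this change is the step from compound 1 to compound 3, where an isopropyl enters at the same place in exchange for a 3-aminopropyl that carries a donor and an acceptor; that step was a number 8.2 percentage points lower from compound 1 to compound 3 (within the scatter), within the scatter. The change to compound 4 runs the other way, a hydroxy with one donor and one acceptor entering for the isopropyl, so a small rise of about the same size is expected, not clearly beyond the scatter. For the measured compounds named here, no measured step shows a hydroxy at this place, so the range is kept wide.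

For compound 4 the expected value is 15%, with a range from 5% to 28%, an estimated step of a number 6.4 percentage points higher from compound 3 to compound 4 (within the scatter).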

Compound 4, a percentage reported as activity, at one dose (the size of the read-out at that dose, not a potency): 34.5%
The estimate for compound 4 lay 19.5 percentage points below the measured number; measured number above the stated range.
By their numbers in this assay, from the lowest: compounds 3, 1 and 2 (each within the scatter of the next, the first and the last beyond it); then compound 4.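

In this assay this position proves able to carry more than the small differences seen among the earlier side chains, where only a number 13.4 percentage points lower from compound 2 to compound 3 (beyond the scatter) cleared the scatter. Hydroxymethyl stands clear of all three: the change gives a number 25.9 percentage points higher from compound 3 to compound 4 (beyond the scatter) as the largest step, alongside a number 17.7 percentage points higher from compound 1 to compound 4 (beyond the scatter) and a number 12.5 percentage points higher from compound 2 to compound 4 (beyond the scatter), which makes compound 4 the strongest of the four at this dose. Compound 1 goes against any reading that a donor on the side chain is enough on its own, as its 4-aminobutyl leaves it within the scatter of compound 2 and compound 3, and nothing measured on these compounds speaks to the cause of the rise.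

Open, going by these compounds, is whether the rise belongs to the hydroxy group itself or to the shorter chain, which a methyl, a longer hydroxyethyl chain or a carboxylic acid at the same place would help to separate. Also open is whether the order of the four holds at other doses and times, as the compounds shown carry a single read-out.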